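Capping a Ring Nitrogen: From Compound 2 to Compound 4

This account rests on a few compounds, and the source may have more. Where it says the series, first, only, none or still open, it means among the compounds named here.

Three compounds sharing one core were tested in a functional assay on MDA-MB-231 cells (Homo sapiens) for inhibition, read by sulforhodamine B assay, tested at 10 uM; a higher number here means more inhibition at the concentration tested (going by the name of the read-out), a lower number less inhibition. Compound 1 `CN1CCN(c2ccc(C3=NNC(c4ccc(N(C)C)cc4)C3)cc2)CC1` gives 11.4%. Compound 2 `CN(C)c1ccc(C2CC(c3ccc(-n4ccnc4)cc3)=NN2)cc1` gives 7.6%, the lowest of the three numbers, though its gap to compound 1 stays within the scatter: a number 3.8 percentage points lower from compound 1 to compound 2 (within the scatter). Compound 3 `CN1CCN(c2ccc(C3=NN(S(=O)(=O)c4ccc(Br)cc4)C(c4ccc(N(C)C)cc4)C3)cc2)CC1` gives 23.7%, and the step of a number 12.3 percentage points higher from compound 1 to compound 3 (beyond the scatter) is the only one beyond the scatter.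

Compound 4 `CN(C)c1ccc(C2CC(c3ccc(-n4ccnc4)cc3)=NN2C(=O)c2ccc(C(F)(F)F)cc2)cc1` differs from compound 2 by (4-(trifluoromethyl)phenyl)carbonyl in place of hydrogen on an amine nitrogen in a ring. For the measured compounds named here, the single measured step that bears on this is a number 12.3 percentage points higher from compound 1 to compound 3 (beyond the scatter), where a (4-bromophenyl)sulfonyl group replaced hydrogen on the same amine nitrogen in a ring and raised inhibition modestly. The group entering here is a different one, a (4-(trifluoromethyl)phenyl)carbonyl, so that step is only a rough guide, but it points upward. Compound 4 is therefore expected to show a modest rise, a number 10.4 percentage points higher from compound 2 to compound 4 (beyond the scatter). The estimate for compound 4 is 18%, with a range from 5% to 35%.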

Compound 4, a percentage reported as inhibition, at one concentration (the size of the read-out at that concentration, not a potency): 17.9%
The estimate for compound 4 lay 0.1 percentage points above the measured number; measured number inside the range.
By their numbers in this assay, from the lowest: compounds 2, 1, 4 and 3 (each within the scatter of the next, the first and the last beyond it).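

Adding a group to this amine nitrogen in a ring now raises the number in a second pair of compounds: this assay shows a number 10.3 percentage points higher from compound 2 to compound 4 (beyond the scatter) and this step is modest. For the compounds shown here, the only earlier step of this kind brought in (4-bromophenyl)sulfonyl with a 4-methylpiperazin-1-yl group elsewhere on the molecule, whereas this one brings in (4-(trifluoromethyl)phenyl)carbonyl with a 1H-imidazol-1-yl group there, so the upward direction holds for two different entering groups and two different molecular backgrounds. Nothing available explains why the number rises in either pair.

Still open, going by these compounds, is whether the carbonyl alone is enough, as a small acetyl group on this nitrogen would show, or whether the aromatic ring and its trifluoromethyl group also contribute, as a plain benzoyl group would show. On these data alone, a reading at one concentration also gives no potency, so how these compounds compare across a range of concentrations remains unknown.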